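The source may report more compounds than this note shows. Statements on the series, on what has been measured and on what is new or still open speak of the compounds shown alone.

Measured compounds in a functional assay on DU-145 cells (Homo sapiens) for cytotoxicity, read by sulforhodamine B assay, with a stated time of 48 h; on this read-out higher numbers stand for weaker inhibition of growth and lower numbers for stronger inhibition of growth:
compound 1 `CC(=O)N1CCN(c2nc(Nc3ccc(C#N)c(C(F)(F)F)c3)nc(Oc3ccnc4ccccc34)n2)CC1`, 75100 nM
compound 2 `CCN1CCN(c2nc(Nc3ccc(C#N)c(C(F)(F)F)c3)nc(Oc3ccnc4ccccc34)n2)CC1`, 86600 nM

Compound 2 stands at 86600 nM in this assay, with compound 1 alongside it at 75100 nM; the step of a 1.2-fold higher number from compound 1 to compound 2 (0.06 log units; within the scatter) is within the scatter. Compound 3 `COc1ccc(N2CCN(c3nc(Nc4ccc(C#N)c(C(F)(F)F)c4)nc(Oc4ccnc5ccccc45)n3)CC2)cc1` differs from compound 2 by 4-methoxyphenyl in place of ethyl on an amine nitrogen in a ring. Among the measured compounds shown here, the only measured step touches the same ring nitrogen but exchanges two small groups and shows no effect beyond the scatter; no measured step brings an aryl group onto that nitrogen. The expected step of a 1.1-fold lower number from compound 2 to compound 3 (0.03 log units; within the scatter) is therefore of unknown direction and set near zero, with a wide range. Compound 3 is estimated at 80000 nM, range 25000 nM to 200000 nM.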

Compound 3, concentration for 50% growth inhibition: > 100000 nM
Compound 3: a limit, no number; the forecaster's own chance of this, stated with the estimate: 25%; middle value at least 1.2-fold (0.09 log units) away from the limit.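

Compound 3 gives > 100000 nM in this assay, which is a limit of the assay and not a number. With 4-methoxyphenyl on the amine nitrogen in the ring, the steps are floors only: an at least 1.1-fold higher number from compound 2 to compound 3 (0.06 log units; that floor lies within the scatter) and an at least 1.3-fold higher number from compound 1 to compound 3 (0.12 log units; that floor lies within the scatter). An aryl group on this nitrogen therefore brings no stronger inhibition of growth, but the true size of either step cannot be read.

As far as these compounds go, whether a longer chain or a benzyl group on that nitrogen would move the number beyond the scatter stays open. So does how far compound 3 truly lies from compound 2.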